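Replacing the thiadiazole on the thioether with an imidazole

The compounds below may be only part of what the source reports. "The series", "measured", "known", "first", "only" and "open" are said of these compounds alone.

Three compounds were measured in a functional assay on MCF7 cells (Homo sapiens) for cytotoxicity, read by MTT assay, with a stated time of 24 h, tested at 6.4 ug/mL; a higher number here means a stronger effect of the compound at the concentration tested, a lower number a weaker effect:
Compound 3 `Cc1nnc(SCC(=O)Nc2ccc(-c3nc(-c4ccccc4)c(-c4ccccc4)n3C)cc2)s1` gives 67.8%
Compound 1 `Cn1c(-c2ccc(NC(=O)CSc3nc4cc(Cl)ccc4o3)cc2)nc(-c2ccccc2)c1-c1ccccc1` gives 27.7%
Compound 2 `Cn1c(-c2ccc(NC(=O)CSc3nc4ccccc4s3)cc2)nc(-c2ccccc2)c1-c1ccccc1` gives 27%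

Compound 3 stands highest of the three: a number 40.1 percentage points higher from compound 1 to compound 3 (beyond the scatter) and a number 40.8 percentage points higher from compound 2 to compound 3 (beyond the scatter), whereas a number 0.7 percentage points lower from compound 1 to compound 2 (within the scatter). Compound 4 `Cn1ccnc1SCC(=O)Nc1ccc(-c2nc(-c3ccccc3)c(-c3ccccc3)n2C)cc1` differs from compound 3 in one place: 1-methyl-1H-imidazol-2-yl in place of 5-methyl-1,3,4-thiadiazol-2-yl on a sulfur. Going by the values given here, no measured step exchanges these two groups. The two large steps both replaced a benzo-fused ring by the small ring of compound 3, and compound 4 keeps a small ring, so only a modest move is expected in this assay, most likely downward but possibly none beyond the scatter. Compound 4 is therefore estimated at 50% (range 24% to 74%), which would mean a number 17.8 percentage points lower from compound 3 to compound 4 (beyond the scatter).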

Compound 4, a percentage reported as activity, at one concentration (the size of the read-out at that concentration, not a potency): 27.2%
Compound 4: middle estimate off by 22.8 percentage points, on the high side; the measured number falls inside the stated range.
By their numbers in this assay, from the lowest: compounds 2, 4 and 1 (each within the scatter of the next); then compound 3.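

In this assay the group 1-methyl-1H-imidazol-2-yl, also six heavy atoms in one five-membered aromatic ring, did not hold the level of compound 3, with a number 40.6 percentage points lower from compound 3 to compound 4 (beyond the scatter) on this sulfur. Compound 4 instead sits with the two larger groups, with a number 0.2 percentage points higher from compound 2 to compound 4 (within the scatter) and a number 0.5 percentage points lower from compound 1 to compound 4 (within the scatter) so a small ring alone is not enough, and among the four only 5-methyl-1,3,4-thiadiazol-2-yl stands apart. Nothing available here accounts for this.

On these data alone, whether the level of compound 3 depends on the ring sulfur or on the ring methyl stays open. The compounds shown also cannot say how a 1,3,4-oxadiazol-2-yl ring or an unsubstituted 1,3,4-thiadiazol-2-yl ring would read.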